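A few compounds are considered here, and "the series" means these few. Any claim that something is new, unique, unknown or untested is made for them only; others in the source may bear on it.

Of the compounds shown here, two with a shared core have been tested in an ADME assay on Vero cells (Chlorocebus sabaeus) for cytotoxicity, read by microscopy; a higher number here means that more compound is tolerated, a lower number that less compound is tolerated. Compound 1 `CSc1nc(NCCCCNc2ccnc3cc(Cl)ccc23)c(C#N)c(-c2cccc([N+](=O)[O-])c2)n1` gives 20000 nM in this assay, and compound 2 `CSc1nc(NCCCCNc2ccnc3cc(Cl)ccc23)c(C#N)c(-c2ccc([N+](=O)[O-])cc2)n1` gives 4000 nM. Among the measured compounds shown here, the only measured step is a 5.0-fold lower number from compound 1 to compound 2 (0.70 log units; beyond the scatter), which came with the change of 4-nitrophenyl in place of 3-nitrophenyl on an aromatic carbon. Compound 2 therefore stands at the lower of the two numbers, with compound 1 the nearer and only neighbour, higher by that step.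

Compound 3 `COc1ccc(-c2nc(SC)nc(NCCCCNc3ccnc4cc(Cl)ccc34)c2C#N)cc1OC` is not yet measured. It differs from compound 2 by 3,4-dimethoxyphenyl in place of 4-nitrophenyl on an aromatic carbon. For the measured compounds named here, the one measured step bears only loosely on this change: it moved the nitro group around the ring rather than replacing it, so it shows how sensitive this assay is to that part of the molecule, but not the direction a 3,4-dimethoxyphenyl will take. The expectation is a step of a 2.5-fold higher number from compound 2 to compound 3 (0.40 log units; beyond the scatter), with the number drifting back toward where compound 1 stands and with wide uncertainty. Compound 3 is therefore estimated at 10000 nM, in a range from 3000 nM to 40000 nM.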

Compound 3, minimum cytotoxic concentration: > 100000 nM
Compound 3 was reported as a limit; the forecaster's own chance of this, stated with the estimate: 15%; middle value at least 10-fold (1.00 log units) away from the limit.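

The place ortho to a cyano group matters more than the shift of the nitro group alone suggested: in this assay, exchanging 4-nitrophenyl for 3,4-dimethoxyphenyl gives an at least 25-fold higher number from compound 2 to compound 3 (1.39 log units; beyond the scatter), and exchanging 3-nitrophenyl for the same group gives an at least 5.0-fold higher number from compound 1 to compound 3 (0.69 log units; beyond the scatter). Compound 3 gives > 100000 nM, which is a limit of the assay and not a number. Both steps are therefore minimum sizes, and their full extent cannot be stated, because the reading for compound 3 ends at a limit: the limit of > 100000 nM in this assay, at which 1 of the 3 values shown sits.

Among the compounds shown here, with only two nitrophenyl groups and one 3,4-dimethoxyphenyl group to compare, it stays open whether the higher tolerated concentration goes with losing the nitro group, with gaining the two methoxy groups, or with both. From the compounds shown here alone, it is also open where a plain phenyl ring, a phenyl ring with a single methoxy group, or a phenyl ring with an amine in place of the nitro group would fall in this assay.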